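Extending the Alkyne Terminus with a Hydroxybutyl Chain

The source may report more compounds than this note shows. Statements on the series, on what has been measured and on what is new or still open speak of the compounds shown alone.

Measured compounds:
- compound 1 `CN1CCC[C@H]1COc1cncc(C#CCCCCF)c1`: 88000 nM
- compound 2 `C#Cc1cncc(OC[C@@H]2CCCN2C)c1`: 6800 nM

In an assay on a protein complex for binding affinity to Neuronal acetylcholine receptor; alpha3/beta4 (Rattus norvegicus) (on this read-out higher numbers stand for weaker inhibition and lower numbers for stronger inhibition), compound 2 gives the lowest of the two numbers, with compound 1 the nearest at 88000 nM. Compound 3 `CN1CCC[C@H]1COc1cncc(C#CCCCCO)c1` carries 4-hydroxybutyl in place of hydrogen on a triple-bonded carbon. Within the data shown here, the one step that bears on this change is a 13-fold lower number from compound 1 to compound 2 (1.11 log units; beyond the scatter), which removed a chain of the same length from the same carbon. Reversing that direction with a related chain, an increase of similar size is expected in this assay, namely a 7.4-fold higher number from compound 2 to compound 3 (0.87 log units; beyond the scatter). Compound 3 is therefore estimated at 50000 nM, within the range 15000 nM to 200000 nM.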

Compound 3, inhibition constant: 63000 nM
Compound 3: the middle estimate sits 1.3-fold (0.10 log units) below what was measured; the range from low to high includes it.
By their numbers in this assay, from the lowest: compound 2; then compounds 3 and 1 (each within the scatter of the next).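

In this assay, 4-hydroxybutyl on the triple-bonded carbon gives a clearly higher number than hydrogen (a 9.3-fold higher number from compound 2 to compound 3 (0.97 log units; beyond the scatter)), so a second chain of this length, not only the 4-fluorobutyl chain, goes with the weaker result. Hydroxy in place of fluoro on the saturated chain carbon makes no difference that can be read (a 1.4-fold lower number from compound 1 to compound 3 (0.15 log units; within the scatter)). No measurement shown explains either result. On these data alone, whether a shorter chain on this carbon behaves like hydrogen remains open, as does whether an amine or a carboxylic acid in place of hydroxy would change the number.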